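Moving a chlorine on the benzyl arm: expected effect in rats

The source may report more compounds than this note shows. Statements on the series, on what has been measured and on what is new or still open speak of the compounds shown alone.

Three compounds sharing one core were tested in a functional assay on the whole organism (artery, strain albino) with Rattus norvegicus as the target, with a stated time of 300 min, at a dose of 10 mg/kg by the oral route; on this read-out lower numbers stand for less inhibition and higher numbers for more inhibition at the one dose given (going by the name of the read-out). Compound 1, `CC1=C(C(=O)Nc2ccc(Br)cc2)C(c2ccc(Cl)cc2Cl)N=C(SCc2ccccc2Cl)N1`, gives 36.4% in this assay. Compound 2, `CC1=C(C(=O)Nc2ccc(Br)cc2)C(c2ccc(Cl)cc2Cl)N=C(SCc2cccc(Cl)c2)N1`, gives 18.5% in this assay. Compound 3, `COc1ccc(C2N=C(SCc3ccccc3Cl)NC(C)=C2C(=O)Nc2ccc(Br)cc2)cc1`, gives 17.9% in this assay.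

Two single changes connect these compounds. From compound 1 to compound 2 the change is 3-chlorophenyl in place of 2-chlorophenyl on a saturated chain carbon bound to a sulfur, and this assay moves by a number 17.9 percentage points lower from compound 1 to compound 2 (beyond the scatter). From compound 1 to compound 3 the change is 4-methoxyphenyl in place of 2,4-dichlorophenyl on a saturated ring carbon, and this assay moves by a number 18.5 percentage points lower from compound 1 to compound 3 (beyond the scatter). Compound 2 and compound 3 stand close together, with no useful order between them.

Compound 4, `COc1ccc(C2N=C(SCc3cccc(Cl)c3)NC(C)=C2C(=O)Nc2ccc(Br)cc2)cc1`, has not been measured. It differs from compound 3 by 3-chlorophenyl in place of 2-chlorophenyl on a saturated chain carbon bound to a sulfur, the same change already seen from compound 1 to compound 2, placed in the same spot; the two cores differ by 4-methoxyphenyl in place of 2,4-dichlorophenyl on a saturated ring carbon.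

Because the earlier change gave a number 17.9 percentage points lower from compound 1 to compound 2 (beyond the scatter), a step of similar size is expected from compound 3 to compound 4, namely a number 10.9 percentage points lower from compound 3 to compound 4 (beyond the scatter), though a read-out near the bottom of the scale cannot fall as far, so the expected step is expected to be smaller. Compound 4 is therefore expected to give about 7% in this assay, with a plausible range from 0% to 20%. This estimate rests on one pair only, compound 1 and compound 2.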

Compound 4, a percentage reported as inhibition, in the whole organism at one dose (the size of the read-out at that dose, not a potency): 39%
Beside the measured number, compound 4's estimate is 32 percentage points below it, outside the stated range (above it).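

On the core carrying 4-methoxyphenyl, going from 2-chlorobenzyl to 3-chlorobenzyl gives a number 21.1 percentage points higher from compound 3 to compound 4 (beyond the scatter), so this change does not carry over from the core of compound 1 and instead runs in the opposite direction: the same change on two cores in this assay, a number 17.9 percentage points lower (beyond the scatter) from compound 1 to compound 2 and a number 21.1 percentage points higher (beyond the scatter) from compound 3 to compound 4, 39 percentage points apart, beyond the scatter of two such steps

The change on the saturated ring carbon behaves the same way, giving a number 20.5 percentage points higher from compound 2 to compound 4 (beyond the scatter) with 3-chlorobenzyl in place, the reverse of what it did with 2-chlorobenzyl: the same change on two cores in this assay, a number 18.5 percentage points lower (beyond the scatter) from compound 1 to compound 3 and a number 20.5 percentage points higher (beyond the scatter) from compound 2 to compound 4, 39 percentage points apart, beyond the scatter of two such steps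

Together these results show that, in these four compounds, the effect of each change depends on which group stands at the other place, so the two steps cannot simply be added, but they do not show why this happens, and a single set of four compounds cannot show whether it is a general feature of the series.

On these data alone, it stays open whether the same reversal would appear with a plain phenyl on the saturated ring carbon, or with an unsubstituted benzyl or a longer chain on the sulfur. Also open is whether the order of these compounds would hold at other doses or at other times after dosing.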